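The source may report more compounds than this note shows. Statements on the series, on what has been measured and on what is new or still open speak of the compounds shown alone.

For the measured compounds named here, compound 1 `NC(=O)N(O)CC1COc2ccccc2O1` gives 18000 nM in an assay (Cavia porcellus) for inhibition of Polyunsaturated fatty acid 5-lipoxygenase (Homo sapiens) (on this read-out lower numbers stand for stronger inhibition and higher numbers for weaker inhibition), the highest of the two numbers so far. Its nearest neighbour, compound 2 `O=C(NCc1ccccc1)N(O)CC1COc2ccccc2O1`, gives 2700 nM in this assay, and the step of a 6.7-fold lower number from compound 1 to compound 2 (0.82 log units; beyond the scatter) came from a benzyl in place of hydrogen on an amide-type nitrogen. Compound 3 `NC(=O)N(O)CC1COc2ccc(Oc3ccccc3)cc2O1` instead carries phenoxy in place of hydrogen on an aromatic carbon. Going by the values given here, no measured step touches that aromatic ring, so the benzyl step is only a loose guide. A moderate lowering is nevertheless expected, a 4.0-fold lower number from compound 1 to compound 3 (0.60 log units; beyond the scatter). Compound 3 is therefore estimated at 4500 nM, with a range from 1000 nM to 20000 nM.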

Compound 3, half-maximal inhibitory concentration: 120 nM
The estimate for compound 3 lay 38-fold (1.57 log units) above the measured number; the whole stated range lies above it.
By their numbers in this assay, from the lowest: compound 3; then compound 2; then compound 1.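

Phenoxy in place of hydrogen on this aromatic carbon gives a 150-fold lower number from compound 1 to compound 3 (2.18 log units; beyond the scatter), so in this assay a change on the aromatic ring of the shared core can count for far more than the earlier change on the amide-type nitrogen, which gave a 6.7-fold lower number from compound 1 to compound 2 (0.82 log units; beyond the scatter). Nothing measured here explains the size of this step. On these data alone, it remains open whether the whole phenoxy group is needed or whether a smaller methoxy group or an amine on the same carbon would do the same. As far as these compounds go, whether the phenoxy and benzyl steps add up in one compound also remains open.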